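Replacing a methyl by piperidinyl on an amide side chain

The source may report more compounds than this note shows. Statements on the series, on what has been measured and on what is new or still open speak of the compounds shown alone.

Two compounds have been measured in an ADME assay on MT4 cells (Homo sapiens) for cytotoxicity, read by MTT assay, with a stated time of 96 h; a higher number here means that more compound is tolerated, a lower number that less compound is tolerated:

Compound 1 `O=[N+]([O-])c1ccc(-c2nc3cc(C(F)(F)F)ccc3[nH]2)cc1` gives 6000 nM.
Compound 2 `CCC(=O)Nc1ccc(-c2nc3cc(C(F)(F)F)ccc3[nH]2)cc1` gives >= 100000 nM.

For compound 2 this value is a limit of the assay, not a number, resting at the limit of >= 100000 nM in this assay, at which 1 of the 2 values shown sits. For the measured compounds named here, the single measured step, an at least 16-fold higher number from compound 1 to compound 2 (1.22 log units; beyond the scatter), concerns a different part of the molecule.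

Compound 3 `O=C(CN1CCCCC1)Nc1ccc(-c2nc3cc(C(F)(F)F)ccc3[nH]2)cc1` differs from compound 2 by piperidin-1-yl in place of methyl on a saturated chain carbon bound to a carbonyl carbon. Going by the values given here, no measured step covers this change, so the expectation rests on compound 2 standing at the limit. Compound 3 is expected to stay in the same region, with an estimated 80000 nM and a range from 20000 nM to 200000 nM. The expected step is an at least 1.2-fold lower number from compound 2 to compound 3 (0.09 log units; that floor lies within the scatter).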

Compound 3, half-maximal cytotoxic concentration: 6000 nM
Beside the measured number, compound 3's estimate is 13-fold (1.12 log units) above it; measured number below the stated range.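

Putting piperidin-1-yl in place of methyl on the saturated chain carbon bound to the carbonyl carbon gives, in this assay, an at least 16-fold lower number from compound 2 to compound 3 (1.22 log units; beyond the scatter). The far end of the amide side chain therefore also affects how much compound the cells tolerate, which compounds 1 and 2 could not show. The true size of this step is unknown, since the value of compound 2 is a limit and not a number: the limit of >= 100000 nM in this assay, at which 1 of the 3 values shown sits.

Going by these compounds, it remains open whether the ring or its nitrogen drives the change. A dimethylamino group or a cyclohexyl ring at this place would help separate the two.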